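Series notes: the step from compound 3 to compound 4

This account rests on a few compounds, and the source may have more. Where it says the series, first, only, none or still open, it means among the compounds named here.

Measured so far in a functional assay on HT-29 cells (Homo sapiens) for inhibition, read by MTT assay, with a stated time of 72 h; a higher number here means a weaker inhibitor of growth, a lower number a stronger inhibitor of growth:
compound 1 `CC(C)(C)c1ccc(CNCCCNS(=O)(=O)c2cc(C(F)(F)F)cc(C(F)(F)F)c2)cc1` gives 2000 nM
compound 2 `O=S(=O)(NCCCNCc1ccccc1)c1cc(C(F)(F)F)cc(C(F)(F)F)c1` gives 15000 nM
compound 3 `COc1cccc(CNCCCNS(=O)(=O)c2cc(C(F)(F)F)cc(C(F)(F)F)c2)c1` gives 10000 nM

Compound 3 stands second highest of the three numbers in this assay. Its nearest neighbour is compound 2, the step being a 1.5-fold lower number from compound 2 to compound 3 (0.18 log units; within the scatter), which is within the scatter; its furthest is compound 1, the step being a 5.0-fold higher number from compound 1 to compound 3 (0.70 log units; beyond the scatter), which is beyond it.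

The next compound is compound 4 `O=S(=O)(NCCCNCc1ccc(Cl)cc1)c1cc(C(F)(F)F)cc(C(F)(F)F)c1`. The change is 4-chlorophenyl in place of 3-methoxyphenyl on a saturated chain carbon bound to an amine nitrogen. Going by the values given here, two measured steps bear on this. The step of a 7.5-fold higher number from compound 1 to compound 2 (0.88 log units; beyond the scatter) shows that a group on the ring moved the number well beyond the scatter, whereas the step of a 1.5-fold lower number from compound 2 to compound 3 (0.18 log units; within the scatter) shows that methoxy moved it no further than the scatter. Chlorine is neither hydrogen nor tert-butyl, so the expected step is a 1.7-fold lower number from compound 3 to compound 4 (0.22 log units; within the scatter), a modest move toward a lower number, because compound 1 gives 2000 nM while compound 2 gives 15000 nM. Compound 4 is estimated at 6000 nM, with a range from 2000 nM to 20000 nM.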

Compound 4, concentration for 50% growth inhibition: 2800 nM
For compound 4 the middle estimate is 2.1-fold (0.33 log units) above the measured one, within the range that was stated.
By their numbers in this assay, from the lowest: compounds 1 and 4 (each within the scatter of the next); then compounds 3 and 2 (each within the scatter of the next).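

Chloro in place of hydrogen on an aromatic carbon gives a 5.4-fold lower number from compound 2 to compound 4 (0.73 log units; beyond the scatter) and so is the first ring group other than tert-butyl shown to clear the scatter. In this assay chloro in place of tert-butyl gives a 1.4-fold higher number from compound 1 to compound 4 (0.15 log units; within the scatter) and stays within the scatter, so the two groups are not separated here. Going from 3-methoxybenzyl to 4-chlorobenzyl gives a 3.6-fold lower number from compound 3 to compound 4 (0.55 log units; beyond the scatter) as well, so the choice of ring group at this place does move the number, while methoxy remains the one group shown within the scatter of hydrogen.

As far as these compounds go, whether bromo or a nitrile in place of chloro would hold the number stays open. No measurement shown accounts for these steps.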